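The source may report more compounds than this note shows. Statements on the series, on what has been measured and on what is new or still open speak of the compounds shown alone.

Measured in a functional assay on L1210 cells (Mus musculus) for inhibition, read by cell counting, with a stated time of 2 days; on this read-out higher numbers stand for weaker inhibition and lower numbers for stronger inhibition:

compound 1 `COc1ccc(-c2nn3cc(-c4cccc(N)c4)nc3s2)cc1OC` — 16000 nM
compound 2 `C=C(Br)C(=O)Nc1cccc(-c2cn3nc(-c4ccc(C)cc4)sc3n2)c1` — 920 nM
compound 3 `Nc1cccc(-c2cn3c(-c4ccc(Cl)cc4)csc3n2)c1` — 22000 nM

Compound 2 holds the lowest number of the three; the nearest, compound 1, and the furthest, compound 3, both lie beyond the scatter above it. Compound 4 `C=C(Br)C(=O)Nc1cccc(-c2cn3nc(-c4cccs4)sc3n2)c1` differs from compound 2 in one place: thiophen-2-yl in place of 4-methylphenyl on an aromatic carbon. Among the measured compounds shown here, no step between measured compounds shares this change, so there is no measured precedent to lean on. The expectation is a step toward a somewhat higher number in this assay, small enough to sit within or only just beyond the scatter. The expected step is a 1.4-fold higher number from compound 2 to compound 4 (0.15 log units; within the scatter). Compound 4 is estimated at 1300 nM, with a range from 400 nM to 4000 nM.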

Compound 4, half-maximal inhibitory concentration: 170 nM
Beside the measured number, compound 4's estimate is 7.6-fold (0.88 log units) above it; measured number outside the range, below it.
By their numbers in this assay, from the lowest: compound 4; then compound 2; then compounds 1 and 3 (each within the scatter of the next).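

In this assay, among the compounds shown here, thiophen-2-yl in place of 4-methylphenyl gives a 5.4-fold lower number from compound 2 to compound 4 (0.73 log units; beyond the scatter), the first single-place comparison. This aromatic carbon, next to the ring nitrogen and next to the ring sulfur, therefore responds to the ring placed on it, and a five-membered aromatic ring with one hetero atom is accepted there. Nothing at hand accounts for the size of this step. On these data alone, whether the gain is specific to thiophen-2-yl remains open. As far as these compounds go, how furan-2-yl, pyridin-3-yl or a simple methyl would read at this carbon also remains open.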